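Flat tolerance at the carbamate ester tail

The compounds below may be only part of what the source reports. "The series", "measured", "known", "first", "only" and "open" are said of these compounds alone.

Measured so far:
compound 1 `O=C(OCCCc1ccccc1)N(c1ccccc1)C1CN2CCC1CC2` — 260 nM
compound 2 `COc1ccc(CCOC(=O)N(c2ccccc2)C2CN3CCC2CC3)cc1` — 230 nM
compound 3 `O=C(OCCc1ccccc1)N(c1ccccc1)C1CN2CCC1CC2` — 260 nM

All three share one core and differ only in the chain carried by the carbamate oxygen. In an assay on CHO cells for displacement of a labelled ligand from muscarinic acetylcholine receptor M5 (Homo sapiens), read by scintillation counting, with a stated time of 2 h (on this read-out higher numbers stand for weaker inhibition and lower numbers for stronger inhibition), compound 3 gives 260 nM, level with compound 1 and together the highest of the three numbers; its nearest neighbour is compound 1 with no change at the digits printed from compound 1 to compound 3 (within the scatter), and its furthest is compound 2, with a 1.1-fold higher number from compound 2 to compound 3 (0.05 log units; within the scatter). For the measured compounds named here, none of the measured steps leaves the scatter.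

Compound 4 `O=C(OCc1ccc(Cl)c(Cl)c1)N(c1ccccc1)C1CN2CCC1CC2` has not been measured. It differs from compound 3 by 3,4-dichlorophenyl in place of benzyl on a saturated chain carbon bound to an oxygen next to a carbonyl group. Going by the values given here, two steps bear on this change. Shortening the chain at the same place, no change at the digits printed from compound 1 to compound 3 (within the scatter), did nothing; adding a group to the ring, a 1.1-fold higher number from compound 2 to compound 3 (0.05 log units; within the scatter), did nothing either. Neither step tests chlorine nor this shorter chain length, so the bearing is indirect.

Given that flatness, compound 4 is expected to give 300 nM in this assay, within 100 nM to 900 nM, a step of a 1.2-fold higher number from compound 3 to compound 4 (0.06 log units; within the scatter) that is estimated to stay close to the scatter.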

Compound 4, inhibition constant: 60 nM
The estimate for compound 4 lay 5.0-fold (0.70 log units) above the measured number; measured number below the stated range.
By their numbers in this assay, from the lowest: compound 4; then compounds 2, 1 and 3 (each within the scatter of the next).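

For the compounds shown here, the tail on the carbamate oxygen is not as flat as the first three compounds suggested: in this assay, the change from phenethyl to 3,4-dichlorobenzyl brings a 4.3-fold lower number from compound 3 to compound 4 (0.64 log units; beyond the scatter) and is the first step to leave the scatter. The picture is the same against the other two tails, with a 3.8-fold lower number from compound 2 to compound 4 (0.58 log units; beyond the scatter) and a 4.3-fold lower number from compound 1 to compound 4 (0.64 log units; beyond the scatter) on the read-out, so compound 4 holds the lowest number of the four, and this position responds to a change that the earlier swaps of chain length and ring methoxy did not reveal. No measurement at hand accounts for this step.

The step alters two things at once, the chain length and the two chlorines on the ring, and the compounds shown do not separate them. A plain benzyl on the same oxygen, a ring with a single chlorine, or a phenethyl chain carrying 3,4-dichlorophenyl would show which of the two changes the step follows.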